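Lengthening the Ester Chain on a Cyclohexene Sulfone Core

The compounds below may be only part of what the source reports. "The series", "measured", "known", "first", "only" and "open" are said of these compounds alone.

Two compounds share a core in which an ester carbonyl and a benzyl sulfone sit on the same ring. Compound 1, `CCOC(=O)C1=CCCCC1S(=O)(=O)Cc1ccccc1F`, and compound 2, `COC(=O)C1=CCCCC1S(=O)(=O)Cc1ccc(F)cc1Cl`, were tested in a functional assay on RAW264.7 cells (Mus musculus), read by fluorescence; a higher number here means a weaker inhibitor, a lower number a stronger inhibitor. In this assay compound 1 gives 97 nM, and compound 2 gives 99 nM. Compound 2 stands alongside compound 1, the two numbers within the scatter of repeat measurements, so nothing separates them.

Compound 3, `CCCCOC(=O)C1=CCCCC1S(=O)(=O)Cc1ccc(F)cc1Cl`, has not yet been measured. It differs from compound 2 by propyl in place of hydrogen on a saturated chain carbon bound to an oxygen next to a carbonyl group. Within the data shown here, no measured pair shows what such a change does here. He expects the step from the methyl ester to the butyl ester to be a 1.1-fold higher number from compound 2 to compound 3 (0.05 log units; within the scatter), which is no step beyond the scatter in either direction. Accordingly he estimates that compound 3 will give about 110 nM, within a range from 50 nM to 280 nM.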

Compound 3, half-maximal inhibitory concentration: 103 nM
The estimate for compound 3 lay 1.1-fold (0.03 log units) above the measured number; the range from low to high includes it.
By their numbers in this assay, from the lowest: compounds 1, 2 and 3 (each within the scatter of the next).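

In this assay, propyl in place of hydrogen on a saturated chain carbon bound to an oxygen next to a carbonyl group gives a 1.0-fold higher number from compound 2 to compound 3 (0.02 log units; within the scatter), the first step measured at this position. Among these compounds, on the core of compound 2, then, the change from methoxycarbonyl to butoxycarbonyl leaves no difference that can be told from the scatter, which is more than the earlier compounds could show, as no pair among them differed in one place. No measurement here offers an explanation for this result.

The compounds shown leave open whether a chain longer than butyl, a branched chain such as tert-butyl, or a carboxylic acid or an amide at this position would give a similar number. They also leave open whether the same change would give a similar step on the benzyl group of compound 1.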